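Swapping Hydroxy for Ethylsulfonyl: Expected Cytotoxicity

The source may hold more compounds than are shown below. What is called first, only, known or untested is meant among the compounds shown, and "the series" means these compounds.

Three close relatives have been tested in an ADME assay on HEp-2 cells (Homo sapiens) for cytotoxicity; on this read-out higher numbers stand for lower toxicity in this test and lower numbers for higher toxicity in this test. Compound 1 `N#CCCCn1c(Cn2c(=O)n(C3CC3)c3ccncc32)nc2ccccc21` gives > 151000 nM; 109000 nM (2 entries). For compound 2 `N#CCCCn1c(Cn2c(=O)n(C3CCC3)c3ccncc32)nc2ccccc21` the result is > 258000 nM, which is a limit of the assay. Among the compounds with values here, compound 3 `O=c1n(Cc2nc3ccccc3n2CCCO)c2cnccc2n1C1CC1` gives 245000 nM, the only single number among the three, and all three results sit close together at high concentrations. Compound 4 `CCS(=O)(=O)CCCn1c(Cn2c(=O)n(C3CC3)c3ccncc32)nc2ccccc21` differs from compound 3 by ethylsulfonyl in place of hydroxy on a saturated chain carbon, three bonds along the chain from an aromatic nitrogen. Within the data shown here, no step between two measured compounds is available to guide this change, so the step is expected to be a 1.2-fold lower number from compound 3 to compound 4 (0.09 log units; within the scatter), nothing beyond the usual scatter. Compound 4 is therefore estimated at 200000 nM, with a range from 90000 nM to 400000 nM.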

Compound 4, half-maximal cytotoxic concentration: > 227000 nM
Compound 4 was reported as a limit; the forecaster's own chance of this, stated with the estimate: 40%; at least 1.1-fold (0.05 log units) between middle value and limit.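

Compound 4 is reported only as a limit of the assay, and the step from compound 3 to compound 4 cannot be read. The compounds shown leave open whether ethylsulfonyl in place of hydroxy changes this read-out at all, and by how much.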